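Chloro-for-hydrogen step on the anilino ring of compound 3

A few compounds are considered here, and "the series" means these few. Any claim that something is new, unique, unknown or untested is made for them only; others in the source may bear on it.

Compound 1 `O=[N+]([O-])c1ccc(Oc2c(Cl)cc(S(=O)(=O)N/C(=N\O)Nc3ccc(Cl)cc3)cc2Cl)cc1` and compound 2 `O=[N+]([O-])c1ccc(Oc2c(Cl)cc(S(=O)(=O)N/C(=N\O)Nc3ccc(Cl)cc3)cc2Cl)c(Cl)c1` share one core; compound 3 `Cc1c(S(=O)(=O)/N=C(\S)Nc2ccc(Cl)cc2)sc2ccc(Cl)cc12` sits on a second core, and the difference between the two cores is not broken down here. In a functional assay on TSGH 8302 cells (Homo sapiens) for cytotoxicity (on this read-out higher numbers stand for weaker inhibition and lower numbers for stronger inhibition), compound 1 gives 7 ug/mL and compound 2 gives 7 ug/mL, a step of no change at the digits printed from compound 1 to compound 2 (within the scatter) for the change (chloro in place of hydrogen on an aromatic carbon). Compound 3 gives 55 ug/mL in this assay, the highest number of the three.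

Compound 4 `Cc1c(S(=O)(=O)/N=C(\S)Nc2ccc(Cl)c(Cl)c2)sc2ccc(Cl)cc12` is not yet measured. It differs from compound 3 by chloro in place of hydrogen on an aromatic carbon. This is the same kind of change as that from compound 1 to compound 2, but the surroundings differ: in compound 2 the entering chloro sits ortho to a large group and meta to a nitro group, in compound 4 ortho to a chloro group and meta to a large group.

The expectation rests on the measured pair: because the step of no change at the digits printed from compound 1 to compound 2 (within the scatter) stayed within the scatter, a step of a 1.1-fold lower number from compound 3 to compound 4 (0.04 log units; within the scatter) is estimated here. Compound 4 is therefore expected to give about 50 ug/mL in this assay, between 20 ug/mL and 120 ug/mL.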

Compound 4, half-maximal inhibitory concentration: 59 ug/mL
Beside the measured number, compound 4's estimate is 1.2-fold (0.07 log units) below it; measured number inside the range.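

In this assay, chloro in place of hydrogen gives a 1.1-fold higher number from compound 3 to compound 4 (0.03 log units; within the scatter), and the two steps on the two cores agree: the same change on two cores in this assay, no change at the digits printed (within the scatter) from compound 1 to compound 2 and a 1.1-fold higher number (0.03 log units; within the scatter) from compound 3 to compound 4, 1.1-fold (0.03 log units) apart, within the scatter of two such steps

Within these two pairs, the change carries from one core to the other as a step that cannot be told from the scatter, even though the entering chloro has different surroundings on each core; in compound 4 it stands ortho to a chloro group and meta to a large group. This does not show that the chloro change would stay as flat on other cores or at other places on the ring, since the result rests on a single pair per core in a single assay.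

Open, as far as these compounds go, is whether an amine or a carboxylic acid entering at the same place, turning the 4-chlorophenyl group of compound 3 into a differently substituted phenyl, would give a step beyond the scatter. Also open, from the compounds shown here alone, is whether a methoxy group would behave as chloro does on both cores.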